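What a 3-methoxyphenyl group may do to compound 3

The compounds below may be only part of what the source reports. "The series", "measured", "known", "first", "only" and "open" are said of these compounds alone.

Measured in a functional assay on HepG2 cells (Homo sapiens) for inhibition, read by MTT assay, with a stated time of 24 h; a lower number here means a stronger inhibitor, a higher number a weaker inhibitor:
- compound 1 `CC1(C)[C@H]2CC[C@]1(C)N(Cc1cn(-c3ccccc3Br)nn1)C(=O)C2`: 150 nM
- compound 2 `CC1(C)[C@H]2CC[C@]1(C)N(Cc1cn(-c3ccc(C#N)cc3)nn1)C(=O)C2`: 50 nM
- compound 3 `CC1(C)[C@H]2CC[C@]1(C)N(Cc1cn(-c3ccccc3O)nn1)C(=O)C2`: 120 nM

Compound 3 cannot be told apart from compound 1, as the data show a 1.3-fold lower number from compound 1 to compound 3 (0.10 log units; within the scatter). Against compound 2 it gives a clearly higher number, with a 2.4-fold higher number from compound 2 to compound 3 (0.38 log units; beyond the scatter). It therefore stands second highest of the three, level with compound 1 within the scatter.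

The next structure, compound 4 `COc1cccc(-n2cc(CN3C(=O)C[C@@H]4CC[C@@]3(C)C4(C)C)nn2)c1`, carries 3-methoxyphenyl in place of 2-hydroxyphenyl on an aromatic nitrogen. For the measured compounds named here, no measured compound holds this group, so the best guide is the earlier changes at the same place. The largest of them is a 3.0-fold lower number from compound 1 to compound 2 (0.48 log units; beyond the scatter), which is only a modest step. These steps give no direction for the new group, so no step beyond the scatter is the plain expectation in this assay. The estimated change is a 1.2-fold lower number from compound 3 to compound 4 (0.08 log units; within the scatter). For compound 4 the expected value is 100 nM, with an expected range from 40 nM to 250 nM.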

Compound 4, half-maximal inhibitory concentration: 70 nM
The estimate for compound 4 lay 1.4-fold (0.15 log units) above the measured number; low and high end bracket the measured number.
By their numbers in this assay, from the lowest: compounds 2, 4, 3 and 1 (each within the scatter of the next, the first and the last beyond it).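

In this assay, the hydrogen-bond donor of 2-hydroxyphenyl proves dispensable at this position, since 3-methoxyphenyl has none and the change stays small, with a 1.7-fold lower number from compound 3 to compound 4 (0.23 log units; within the scatter). The new group also sits level with 4-cyanophenyl, with a 1.4-fold higher number from compound 2 to compound 4 (0.15 log units; within the scatter), yet it is separated, if only modestly, from 2-bromophenyl, with a 2.1-fold lower number from compound 1 to compound 4 (0.33 log units; beyond the scatter). Nothing available explains these differences in the cell assay.

This change swaps the group and moves it around the phenyl ring at once, so the compounds shown cannot separate the two effects; 3-hydroxyphenyl or 2-methoxyphenyl would be needed to do that. Going by these compounds, it also remains open whether an aromatic ring is needed here at all, which a cyclohexyl group or a plain butyl chain on the same nitrogen could test.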